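This account rests on a few compounds, and the source may have more. Where it says the series, first, only, none or still open, it means among the compounds named here.

Measured compounds so far:
compound 1, `O=C(Nc1ccc(Oc2ccnc3[nH]ccc23)c(F)c1)c1cc2cccnc2n(-c2ccc(Cl)cc2)c1=O`, in a functional assay on A549 cells (Homo sapiens) for antiproliferative activity, read by MTT assay, with a stated time of 72 h (a lower number here means a stronger inhibitor, a higher number a weaker inhibitor), gives 110 nM
compound 2, `O=C(Nc1ccc(Oc2ccnc3[nH]ccc23)c(F)c1)c1cc2cccnc2n(-c2ccc(Br)cc2)c1=O`, gives 210 nM
compound 3, `Cn1ccc2c(Oc3ccc(NC(=O)c4cc5cccnc5n(-c5ccc(Cl)cc5)c4=O)cc3F)ccnc21`, gives 350 nM

Compound 4, `Cn1ccc2c(Oc3ccc(NC(=O)c4cc5cccnc5n(-c5ccc(Br)cc5)c4=O)cc3F)ccnc21`, is not yet measured. Compound 1 and compound 2 differ by bromo in place of chloro on an aromatic carbon; this step gave a 1.9-fold higher number from compound 1 to compound 2 (0.28 log units; within the scatter). The two cores differ by methyl in place of hydrogen on an aromatic nitrogen; between them the step was a 3.2-fold higher number from compound 1 to compound 3 (0.50 log units; beyond the scatter), so compound 3 stands with the highest of the three numbers, though its gap to compound 2 is within the scatter. Compound 3 and compound 4 differ by bromo in place of chloro on an aromatic carbon; the place is described in the same words as for the pair of compound 1 and compound 2, so this is the same change made on the other core. The step from compound 3 to compound 4 in this assay is expected to be a 1.6-fold higher number from compound 3 to compound 4 (0.20 log units; within the scatter), set beside a 1.9-fold higher number from compound 1 to compound 2 (0.28 log units; within the scatter), and rests on compound 2 at 210 nM against compound 1 at 110 nM. Compound 4 is therefore estimated at 550 nM. For compound 4 the expected range runs from 250 nM to 1200 nM.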

Compound 4, half-maximal inhibitory concentration: 390 nM
Estimate against measurement, compound 4: 1.4-fold (0.15 log units) above; the measured number falls inside the stated range.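

In this assay, bromo in place of chloro on the N-methyl core gives a 1.1-fold higher number from compound 3 to compound 4 (0.05 log units; within the scatter), and this agrees with the same change on the core of compound 1: the same change on two cores in this assay, a 1.9-fold higher number (0.28 log units; within the scatter) from compound 1 to compound 2 and a 1.1-fold higher number (0.05 log units; within the scatter) from compound 3 to compound 4, 1.7-fold (0.23 log units) apart, within the scatter of two such steps. Methyl in place of hydrogen on the aromatic nitrogen gives a 1.9-fold higher number from compound 2 to compound 4 (0.27 log units; within the scatter) in the bromo pair, and this too agrees with the step in the chloro pair: the same change on two cores in this assay, a 3.2-fold higher number (0.50 log units; beyond the scatter) from compound 1 to compound 3 and a 1.9-fold higher number (0.27 log units; within the scatter) from compound 2 to compound 4, 1.7-fold (0.23 log units) apart, within the scatter of two such steps. For the compounds shown here, both changes therefore carry from one core to the other as far as these four compounds can tell, but this does not show that the halogen swap has a real effect on either core, and the size of the methyl step stays loosely fixed, as only one of its two readings lies beyond the scatter.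

The compounds shown leave open whether an amine or a carboxylic acid in place of the halogen on the phenyl ring would also carry across the two cores. They also leave open how a longer chain in place of methyl on the aromatic nitrogen would read.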